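The source may hold more compounds than are shown below. What is called first, only, known or untested is meant among the compounds shown, and "the series" means these compounds.

Compound 3, `COc1ccc(F)cc1CNCCCNc1ccnc2cc(Oc3ccc(Cl)cc3)ccc12`, gives 14500 nM in a physicochemical assay for solubility, with a stated time of 18 h, at pH 7.4 (a higher number here means a more soluble compound, a lower number a less soluble compound), the highest of the three measured numbers; compound 1, `COc1ccc(F)cc1CNCCCNc1ccnc2cc(Cc3ccccc3)ccc12`, gives 4200 nM and compound 2, `COc1ccc(F)cc1CNCCCNc1ccnc2cc(CC3CCCCC3)ccc12`, gives 4200 nM. Compound 4, `COc1ccc(F)cc1CNCCCNc1ccnc2cc(-c3cccc4ccccc34)ccc12`, differs from compound 3 by naphthalen-1-yl in place of 4-chlorophenoxy on an aromatic carbon. Within the data shown here, the steps that bear on this position are a 3.5-fold higher number from compound 1 to compound 3 (0.54 log units; beyond the scatter) and a 3.5-fold higher number from compound 2 to compound 3 (0.54 log units; beyond the scatter), both modest and both pointing toward the 4-chlorophenoxy group as the better of the three. Because compound 1 gives 4200 nM with a benzyl group in this position, and the 4-chlorophenoxy group now leaves and a naphthalen-1-yl group enters, a modest decrease in this assay is expected, a 3.6-fold lower number from compound 3 to compound 4 (0.56 log units; beyond the scatter), back toward the level of compound 1. Compound 4 is therefore estimated at 4000 nM, within a range from 1300 nM to 12000 nM.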

Compound 4, solubility: 32000 nM
Compound 4: the middle estimate sits 8.0-fold (0.90 log units) below what was measured; measured number outside the range, above it.
By their numbers in this assay, from the lowest: compounds 1 and 2 (each within the scatter of the next); then compound 3; then compound 4.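

In this assay, the all-carbon naphthalen-1-yl gives the highest number at this position, above even 4-chlorophenoxy (a 2.2-fold higher number from compound 3 to compound 4 (0.34 log units; beyond the scatter)), so among the compounds shown a high number here does not depend on the hydrogen-bond acceptor of 4-chlorophenoxy. The gain is larger against benzyl (a 7.6-fold higher number from compound 1 to compound 4 (0.88 log units; beyond the scatter)) and against cyclohexylmethyl (a 7.6-fold higher number from compound 2 to compound 4 (0.88 log units; beyond the scatter)). Nothing available explains this rise. The compounds shown leave open how naphthalen-2-yl would compare with naphthalen-1-yl on this aromatic carbon, and whether an amine or a carboxylic acid there would give a higher number still.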